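A few compounds are considered here, and "the series" means these few. Any claim that something is new, unique, unknown or untested is made for them only; others in the source may bear on it.

Compound 1 `O=C(/C=C/c1ccc2c(c1)B(O)OC2)c1cccs1` is one of three compounds with a shared core that have been tested in a toxicity assay on MCF-10A cells (Homo sapiens) for cytotoxicity, read by MTT assay, with a stated time of 48 h; a lower number here means a stronger inhibitor, a higher number a weaker inhibitor. In this assay compound 1 gives 13800 nM, the second highest of the three numbers; compound 2 `CCc1ccc(C(=O)/C=C/c2ccc3c(c2)B(O)OC3)cc1` gives 8800 nM and compound 3 `O=C(/C=C/c1ccc2c(c1)B(O)OC2)c1ccc(OCc2ccccc2)cc1` gives 23300 nM, both lying within the usual scatter of the number for compound 1. Among the measured compounds shown here, the only step between measured compounds, a 2.6-fold higher number from compound 2 to compound 3 (0.42 log units; beyond the scatter), came from benzyloxy in place of ethyl on an aromatic carbon, not from exchanging the ring on the carbonyl carbon. Compound 4 `O=C(/C=C/c1ccc2c(c1)B(O)OC2)c1ccccc1F` differs from compound 1 by 2-fluorophenyl in place of thiophen-2-yl on a carbonyl carbon. For the measured compounds named here, no measured step covers such a ring exchange, so no shift beyond the scatter is expected. The expected step is a 1.2-fold lower number from compound 1 to compound 4 (0.06 log units; within the scatter). Compound 4 is therefore estimated to give 12000 nM, between 5000 nM and 30000 nM.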

Compound 4, half-maximal inhibitory concentration: 25400 nM
For compound 4 the middle estimate is 2.1-fold (0.33 log units) below the measured one, within the range that was stated.
By their numbers in this assay, from the lowest: compounds 2, 1, 3 and 4 (each within the scatter of the next, the first and the last beyond it).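

Among the compounds shown here, this is the first measured exchange of the ring on the carbonyl carbon, and in this assay it gives a 1.8-fold higher number from compound 1 to compound 4 (0.26 log units; within the scatter). Thiophen-2-yl, with its sulfur, can therefore give way to the larger 2-fluorophenyl without a shift beyond the scatter, at least in this one pair. No measurement shown offers an explanation for this step. The compounds shown leave open what the fluorine contributes, since a plain phenyl ring would be needed to separate it from the ring exchange. They also leave open how an amine or a carboxylic acid on this ring would read.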